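The source may hold more compounds than are shown below. What is called first, only, known or untested is meant among the compounds shown, and "the series" means these compounds.

Measured so far in a functional assay on ZR-75-1 cells (Homo sapiens) for cytotoxicity, read by MTT assay, with a stated time of 72 h; a lower number here means that less compound is needed, a higher number that more compound is needed for the effect:
Compound 1, `CCc1cccc2c(OC)c(-c3occ(C)c3CO)ccc12`, gives > 10 ug/mL, which is a limit of the assay and not a number.
Compound 2, `CCOCc1c(C)coc1-c1ccc2c(CC)cccc2c1OC`, gives 9.1 ug/mL.

Among the measured compounds shown here, compound 2 thus holds the only number here; the other value sits at the limit of > 10 ug/mL in this assay, at which 1 of the 2 values shown sits. For the measured compounds named here, the one measured step, an at least 1.0-fold lower number from compound 1 to compound 2 (0.04 log units; that floor lies within the scatter), changed the same saturated carbon and stayed within the scatter. Compound 3, `CCc1cccc2c(OC)c(-c3occ(C)c3CBr)ccc12`, differs from compound 2 by bromo in place of ethoxy on a saturated chain carbon bound to an aromatic carbon. Going by the values given here, no measured step covers that exchange, so the expectation rests on compound 2 alone. The step of a 2.3-fold lower number from compound 2 to compound 3 (0.36 log units; beyond the scatter) is the estimate. Compound 3 is therefore expected near 4 ug/mL, between 1 ug/mL and 10 ug/mL.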

Compound 3, concentration for half-maximal effect: 4.6 ug/mL
Estimate against measurement, compound 3: 1.2-fold (0.06 log units) below; the measured number falls inside the stated range.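

Among the compounds shown here, on this saturated chain carbon bound to an aromatic carbon, bromo in place of hydroxy gives the first step beyond the scatter (an at least 2.1-fold lower number from compound 1 to compound 3 (0.33 log units; beyond the scatter)). Against ethoxy the same bromo stays within the scatter (a 2.0-fold lower number from compound 2 to compound 3 (0.30 log units; within the scatter)), so bromo and ethoxy cannot be put in order here. Compound 1 holds a limit and not a number, so the step from it is only a floor: the limit of > 10 ug/mL in this assay, at which 1 of the 3 values shown sits.

An amine, a carboxylic acid or chloro on this carbon is not among the compounds shown. Going by these compounds, whether the gain belongs to bromo itself or to any replacement of hydroxy therefore stays open.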